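This account rests on a few compounds, and the source may have more. Where it says the series, first, only, none or still open, it means among the compounds named here.

In a functional assay on MDA-MB-231 cells (Homo sapiens) for antiproliferative activity, read by MTT assay, with a stated time of 48 h (a lower number here means a stronger inhibitor, a higher number a weaker inhibitor), compound 1 `COC(=O)/C(=C/c1ccccc1)CN1C(=O)[C@@H](OC)[C@H]1c1ccc(Cl)cc1` gives 15600 nM, compound 2 `COC(=O)/C(=C/c1ccccc1)CN1C(=O)[C@@H](OC)[C@H]1c1ccc(Cl)cc1Cl` gives 19000 nM and compound 3 `COC(=O)/C(=C/c1ccccc1)CN1C(=O)[C@@H](OC)[C@H]1c1ccc(OC)cc1` gives 14000 nM. The steps of a 1.1-fold lower number from compound 1 to compound 3 (0.05 log units; within the scatter) and a 1.4-fold lower number from compound 2 to compound 3 (0.13 log units; within the scatter) show that compound 3 stands level with the other two. Compound 4 `COC(=O)/C(=C/c1ccccc1)CN1C(=O)[C@@H](OC)[C@H]1c1cccc(C(F)(F)F)c1` carries 3-(trifluoromethyl)phenyl in place of 4-methoxyphenyl on a saturated ring carbon. For the measured compounds named here, no measured compound carries trifluoromethyl, so the closest guides are changes at this same group, including a 1.2-fold higher number from compound 1 to compound 2 (0.09 log units; within the scatter). All three stayed within the scatter, so no step beyond the scatter is expected in this assay. The expected change is a 1.1-fold higher number from compound 3 to compound 4 (0.03 log units; within the scatter). For compound 4 the estimated value is 15000 nM, with an expected range from 8000 nM to 28000 nM.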

Compound 4, half-maximal inhibitory concentration: 18200 nM
Compound 4: the middle estimate sits 1.2-fold (0.08 log units) below what was measured; measured number inside the range.
By their numbers in this assay, from the lowest: compounds 3, 1, 4 and 2 (each within the scatter of the next).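

In this assay, the step of a 1.3-fold higher number from compound 3 to compound 4 (0.11 log units; within the scatter) and the step of a 1.2-fold higher number from compound 1 to compound 4 (0.07 log units; within the scatter) and also the step of a 1.0-fold lower number from compound 2 to compound 4 (0.02 log units; within the scatter) all stay within the scatter. So trifluoromethyl, new to this set, gives no separation from the other aromatic groups at this saturated ring carbon, even though 3-(trifluoromethyl)phenyl has no hydrogen-bond acceptor and 4-methoxyphenyl has one. Nothing available explains this flat result. Still open, as far as these compounds go, is whether a phenyl group carrying an amine or a carboxylic acid would move the number, and whether changing the methoxy group on the shared core would matter more.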